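Replacing the benzyl substituent on the ring nitrogen of compound 1

A few compounds are considered here, and "the series" means these few. Any claim that something is new, unique, unknown or untested is made for them only; others in the source may bear on it.

In a functional assay on MKN-74 cells (Homo sapiens) for antiproliferative activity, with a stated time of 24 h (on this read-out lower numbers stand for stronger inhibition and higher numbers for weaker inhibition), compound 1, `NC(=O)c1c(NC(=O)c2ccccc2Cl)sc2c1CCN(Cc1ccc(Cl)cc1Cl)C2`, gives 16300 nM, the highest of the three numbers in this set. Compound 2, `NC(=O)c1c(NC(=O)c2ccc(C(F)(F)F)cc2)sc2c1CCN(Cc1ccc(Cl)cc1Cl)C2`, gives 10900 nM, and compound 3, `NC(=O)c1c(NC(=O)c2ccccc2F)sc2c1CCN(Cc1ccc(Cl)cc1Cl)C2`, gives 9610 nM. The steps among them are a 1.5-fold lower number from compound 1 to compound 2 (0.17 log units; within the scatter), a 1.7-fold lower number from compound 1 to compound 3 (0.23 log units; within the scatter) and a 1.1-fold lower number from compound 2 to compound 3 (0.05 log units; within the scatter); each stays within the scatter, so the three compounds cannot be ordered.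

Compound 4, `NC(=O)c1c(NC(=O)c2ccccc2Cl)sc2c1CCN(C(=O)Nc1c(Cl)cccc1Cl)C2`, differs from compound 1 in one place: (2,6-dichlorophenyl)carbamoyl in place of 2,4-dichlorobenzyl on an amine nitrogen in a ring. All three measured steps change the aryl group on the carbonyl carbon of the amide and leave the 2,4-dichlorobenzyl untouched, so none of them bears on the exchange at the amine nitrogen in the ring. The data therefore give no basis for a direction, and the expected step is none beyond the scatter.

Compound 4 is expected to give 16000 nM in this assay, within a range of 4000 nM to 60000 nM, which means an expected step of a 1.0-fold lower number from compound 1 to compound 4 (0.01 log units; within the scatter).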

Compound 4, half-maximal inhibitory concentration: 24400 nM
Estimate against measurement, compound 4: 1.5-fold (0.18 log units) below, and the stated range covers the measured number.
By their numbers in this assay, from the lowest: compounds 3, 2, 1 and 4 (each within the scatter of the next, the first and the last beyond it).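

Among these compounds, the earlier compounds varied only the aryl group on the carbonyl carbon of the amide, so compound 4 is the first of them to change the substituent on the amine nitrogen in the ring. In this assay the exchange of 2,4-dichlorobenzyl for (2,6-dichlorophenyl)carbamoyl gives a 1.5-fold higher number from compound 1 to compound 4 (0.18 log units; within the scatter) and so shows that a carbonyl and an added hydrogen-bond donor can enter at this nitrogen without a step beyond the scatter. No measurement at hand accounts for this result.

The exchange alters the link to the ring nitrogen and the chlorine pattern together, and these compounds cannot separate the two. As far as these compounds go, how a methyl group, an acetyl group, or a chain ending in an amine or a carboxylic acid would read at this nitrogen remains open.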